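Pyrazoline amides: fluorophenyl position shift across two cores

The source may hold more compounds than are shown below. What is called first, only, known or untested is meant among the compounds shown, and "the series" means these compounds.

Compound 1 `COc1ccc(C2=NN(C(=O)C3COc4ccccc4O3)C(c3cccc(F)c3)C2)cc1` and compound 2 `COc1ccc(C2=NN(C(=O)C3COc4ccccc4O3)C(c3ccc(F)cc3)C2)cc1` share one core and differ only in the fluorophenyl group on the saturated ring carbon. In a functional assay on WM 266-4 cells (Homo sapiens) for inhibition, read by MTT assay, with a stated time of 24 h (on this read-out higher numbers stand for weaker inhibition of growth and lower numbers for stronger inhibition of growth), compound 1 gives 6720 nM, and compound 2 gives 6190 nM. The change between them is 4-fluorophenyl in place of 3-fluorophenyl on a saturated ring carbon, and it produced a 1.1-fold lower number from compound 1 to compound 2 (0.04 log units; within the scatter); the two numbers are therefore treated as equivalent.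

Compound 3 `O=C(c1ccc2c(c1)OCCO2)N1N=C(c2ccc(Br)cc2)CC1c1cccc(F)c1` carries a different core. In this assay compound 3 gives 810 nM, the strongest growth inhibition of the three measured compounds, beyond the scatter relative to both compound 1 and compound 2. How the core of compound 3 differs from the core of compound 1 is not broken down here.

Compound 4 `O=C(c1ccc2c(c1)OCCO2)N1N=C(c2ccc(Br)cc2)CC1c1ccc(F)cc1` has not yet been measured. It differs from compound 3 by 4-fluorophenyl in place of 3-fluorophenyl on a saturated ring carbon. This is the same kind of change as that from compound 1 to compound 2, though not the same: the ring atom two ring bonds from the place bears a 4-bromophenyl group (7 heavy atoms) in compound 3, whereas in compound 1 it bears a 4-methoxyphenyl group (8 heavy atoms).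

For compound 4 a step within the scatter is expected, a 1.1-fold lower number from compound 3 to compound 4 (0.03 log units; within the scatter), because the same change on the other core gave a 1.1-fold lower number from compound 1 to compound 2 (0.04 log units; within the scatter). Compound 4 is therefore estimated at 750 nM, with a range of 350 nM to 1600 nM; a transfer of the pattern between cores is assumed, resting on a single measured pair.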

Compound 4, concentration for 50% growth inhibition: 3260 nM
For compound 4 the middle estimate is 4.3-fold (0.64 log units) below the measured one, outside the stated range (above it).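

In this assay, 4-fluorophenyl in place of 3-fluorophenyl on a saturated ring carbon gives a 4.0-fold higher number from compound 3 to compound 4 (0.60 log units; beyond the scatter), so this change does not behave alike on the two cores: the same change on two cores in this assay, a 1.1-fold lower number (0.04 log units; within the scatter) from compound 1 to compound 2 and a 4.0-fold higher number (0.60 log units; beyond the scatter) from compound 3 to compound 4, 4.4-fold (0.64 log units) apart, beyond the scatter of two such steps. The step read on the core of compound 1 therefore cannot stand in for the step on the core of compound 3, and in this series the position of the fluorine on this phenyl group has to be read core by core. This does not show which difference between the cores goes with the larger step, since compound 1 and compound 3 differ in more than one place, and with a single pair on each core it gives neither the size nor the direction of the step on any further core.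

Open, on these data alone, is whether the 4-bromophenyl group in place of the 4-methoxyphenyl group is enough on its own to bring out the step, or whether the other difference between the cores is needed. Also open, as far as these compounds go, is how the same change behaves when a phenyl group carrying a nitrile or a carboxylic acid stands in place of the 4-bromophenyl group.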